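Benzothiophene Replaces Fluorophenyl on a Hydroxamate Series

This account rests on a few compounds, and the source may have more. Where it says the series, first, only, none or still open, it means among the compounds named here.

compound 1 `O=C(NO)c1ccc(NCc2nc(-c3cccc(Cl)c3)nn2-c2ccccc2)cc1`: 115 nM
compound 2 `O=C(NO)c1ccc(NCc2nc(-c3ccc(F)cc3)nn2-c2ccccc2)cc1`: 115 nM

In an assay on Sf9 cells for inhibition of protein deacetylase HDAC6 (Homo sapiens), read by fluorescence, with a stated time of 40 min (on this read-out higher numbers stand for weaker inhibition and lower numbers for stronger inhibition), compound 2 gives 115 nM, level with compound 1, which gives 115 nM. Among the measured compounds shown here, the only step so far, no change at the digits printed from compound 1 to compound 2 (within the scatter), swapped one substituted phenyl for another at the same aromatic carbon without moving the read-out. Compound 3 `O=C(NO)c1ccc(NCc2nc(-c3cc4ccccc4s3)nn2-c2ccccc2)cc1` makes the change (1-benzothiophen-2-yl in place of 4-fluorophenyl on an aromatic carbon). Since that single step bears on the same position and showed no change, a small step is expected, though a fused bicycle is new here. The expected value for compound 3 is 110 nM (40 nM to 350 nM), a step of a 1.0-fold lower number from compound 2 to compound 3 (0.02 log units; within the scatter).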

Compound 3, half-maximal inhibitory concentration: 324 nM
Estimate against measurement, compound 3: 2.9-fold (0.47 log units) below; the measured number falls inside the stated range.
By their numbers in this assay, from the lowest: compounds 1 and 2 (each within the scatter of the next); then compound 3.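

In this assay, the position on the five-membered aromatic ring with 3 nitrogen, where the two substituted phenyl groups read alike, proved sensitive to its substituent: 1-benzothiophen-2-yl gives a 2.8-fold higher number from compound 2 to compound 3 (0.45 log units; beyond the scatter) and a 2.8-fold higher number from compound 1 to compound 3 (0.45 log units; beyond the scatter). The position therefore does not accept every aromatic group equally, although this step is modest. Nothing available explains the rise.

The compounds shown leave open whether the higher number follows the sulfur-containing ring or the fused bicycle as a whole. A 2-thienyl or a 2-naphthyl group at this carbon would separate the two.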